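Propanoyl to Propylcarbonyl: Compound 3 to Compound 4

The source may report more compounds than this note shows. Statements on the series, on what has been measured and on what is new or still open speak of the compounds shown alone.

In an ADME assay on Vero cells (Chlorocebus sabaeus) for cytotoxicity, read by MTT assay, with a stated time of 24 h (on this read-out lower numbers stand for higher toxicity in this test and higher numbers for lower toxicity in this test), compound 3 `CCC(=O)OCCc1ccc(O)c(O)c1` gives 40 ug/mL, the lower of the two numbers available. Compound 2 `CCCCOC(=O)CCc1ccc(O)c(O)c1` gives 200 ug/mL. The gap between these two compounds lies beyond the scatter. Compound 1 `CCCOC(=O)CCc1ccc(O)c(O)c1` reads > 200 ug/mL, which is a limit of the assay.

Compound 4 `CCCC(=O)OCCc1ccc(O)c(O)c1` differs from compound 3 by methyl in place of hydrogen on a saturated chain carbon, two bonds along the chain from a carbonyl carbon, with methyl in place of hydrogen on a saturated chain carbon, two bonds along the chain from a carbonyl carbon. Within the data shown here, the one measured step that also puts methyl in place of hydrogen lies at a different place, three bonds along the chain from an oxygen next to a carbonyl group. That step is a number no higher from compound 1 to compound 2 (the limit leaves the size open), so it offers no usable size. The expectation therefore starts from compound 3 at 40 ug/mL, and no shift beyond the scatter is expected in this assay. The expected change is a 1.1-fold lower number from compound 3 to compound 4 (0.06 log units; within the scatter). Compound 4 is estimated at 35 ug/mL, with an expected range from 15 ug/mL to 90 ug/mL.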

Compound 4, half-maximal cytotoxic concentration: 100 ug/mL
Compound 4: middle estimate off by 2.9-fold (0.46 log units), on the low side; the measured number lies above the stated range.
By their numbers in this assay, from the lowest: compound 3; then compounds 4 and 2 (each within the scatter of the next).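

In this assay, among these compounds, methyl in place of hydrogen on a saturated chain carbon, two bonds along the chain from a carbonyl carbon, gives the first step of readable size for this change: a 2.5-fold higher number from compound 3 to compound 4 (0.40 log units; beyond the scatter). Going from propanoyl to propylcarbonyl at this position therefore moves the read-out beyond the scatter, towards lower toxicity in this test. The earlier compounds could not show this, and the size of the change on the other core remains unreadable: the same change on two cores in this assay, a number no higher (the limit leaves the size open) from compound 1 to compound 2 and a 2.5-fold higher number (0.40 log units; beyond the scatter) from compound 3 to compound 4; the limit leaves it open whether they differ

From the compounds shown here alone, whether a longer chain at this position would move the number further, or whether it would level off, stays open. With a single readable step here, the compounds shown also leave open how a branched chain or an amine at the same place would read.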